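The source may report more compounds than this note shows. Statements on the series, on what has been measured and on what is new or still open speak of the compounds shown alone.

Measured compounds:
compound 1 `CCc1ccccc1NS(=O)(=O)c1ccc(N2CCNC2=O)cc1` — 350 nM
compound 2 `COc1ccc(NS(=O)(=O)c2ccc(N3CCNC3=O)cc2)cc1OC` — 610 nM
compound 3 `O=C1NCCN1c1ccc(S(=O)(=O)Nc2cccc(Cl)c2)cc1` — 79 nM

All three share one core and differ only in the aryl group on the sulfonamide nitrogen. In a functional assay on MCF7 cells (Homo sapiens) for antiproliferative activity, read by sulforhodamine B assay, with a stated time of 48 h (a higher number here means a weaker inhibitor, a lower number a stronger inhibitor), compound 1 gives 350 nM, the second highest of the three numbers. Compound 2, with 610 nM, sits within the usual scatter of compound 1, so the two cannot be told apart. Compound 3 lies furthest away: a 4.4-fold lower number from compound 1 to compound 3 (0.65 log units; beyond the scatter), a change that reaches beyond the scatter.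

Compound 4 `Cc1ccccc1NS(=O)(=O)c1ccc(N2CCNC2=O)cc1` differs from compound 1 by hydrogen in place of methyl on a saturated chain carbon bound to an aromatic carbon. Among the measured compounds shown here, no measured step follows this particular change; the only step at hand, a 4.4-fold lower number from compound 1 to compound 3 (0.65 log units; beyond the scatter), swaps the whole aryl group and so says little about trimming a chain by one carbon. With nothing pointing in either direction, no step beyond the scatter is expected in this assay. Compound 4 is therefore estimated at about 400 nM, with a likely range from 150 nM to 1100 nM, which would mean an expected 1.1-fold higher number from compound 1 to compound 4 (0.06 log units; within the scatter).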

Compound 4, half-maximal inhibitory concentration: 280 nM
For compound 4 the middle estimate is 1.4-fold (0.15 log units) above the measured one; measured number inside the range.
By their numbers in this assay, from the lowest: compound 3; then compounds 4, 1 and 2 (each within the scatter of the next, the first and the last beyond it).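

Shortening the ethyl of compound 1 to the methyl of compound 4 gives a 1.3-fold lower number from compound 1 to compound 4 (0.10 log units; within the scatter) in this assay, so on this saturated chain carbon, removing one methyl leaves no difference that can be told from the scatter. Replacing the whole aryl group is another matter: 2-methylphenyl in place of 3-chlorophenyl gives a 3.5-fold higher number from compound 3 to compound 4 (0.55 log units; beyond the scatter), so among these compounds the clear differences come with the aryl swap and not with the chain trim. No measured evidence is available to explain either step.

On these data alone, whether a longer chain such as propyl, or an amine in place of the chain, would also leave the number within the scatter remains open. So does whether the step between 3-chlorophenyl and 2-methylphenyl follows the chlorine itself or the place it occupies on the aryl ring.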